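Methyl on the Amide Nitrogen: Expected Effect on Clearance

The source may report more compounds than this note shows. Statements on the series, on what has been measured and on what is new or still open speak of the compounds shown alone.

Compound 2 `O=C(N[C@H]1CN(S(=O)(=O)c2ccccc2)C[C@@H]1C(=O)N[C@H]1CCCNC1)c1cc(-c2ccccc2Cl)on1` gives 8.3 uL/min in an ADME assay on cells (Hepatocyte, Rattus norvegicus) for metabolic stability (a lower number here means slower removal, a higher number faster removal of the compound), the highest of the three numbers shown. Compound 3 `O=C(N[C@H]1CN(S(=O)(=O)c2ccccc2)C[C@@H]1C(=O)N1C[C@H]2CCNC[C@H]21)c1cc(-c2ccccc2Cl)on1` gives 4.7 uL/min, and a 1.8-fold lower number from compound 2 to compound 3 (0.25 log units; within the scatter). Compound 1 `O=C(N[C@H]1CN(S(=O)(=O)c2ccccc2)C[C@@H]1C(=O)N[C@H]1CCCNC1)c1cc(-c2ccc(Cl)cc2)on1` gives 2.22 uL/min, and a 3.7-fold higher number from compound 1 to compound 2 (0.57 log units; beyond the scatter). Compound 4 `CN(C(=O)c1cc(-c2ccccc2Cl)on1)[C@H]1CN(S(=O)(=O)c2ccccc2)C[C@@H]1C(=O)N[C@H]1CCCNC1` differs from compound 2 by methyl in place of hydrogen on an amide-type nitrogen. Going by the values given here, neither measured step touches the amide nitrogen: one puts 2-chlorophenyl in place of 4-chlorophenyl, the other swaps the group on the carbonyl carbon, so no measured step bears directly on this change. The step from compound 2 to compound 4 is therefore expected to stay within the scatter, a 1.0-fold lower number from compound 2 to compound 4 (0.02 log units; within the scatter). Compound 4 is estimated at 8 uL/min, with a range from 4 uL/min to 16 uL/min.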

Compound 4, intrinsic clearance in a liver preparation (reported as CLH), per the amount of preparation that the assay uses: 12 uL/min
For compound 4 the middle estimate is 1.5-fold (0.18 log units) below the measured one; the range from low to high includes it.
By their numbers in this assay, from the lowest: compound 1; then compounds 3, 2 and 4 (each within the scatter of the next, the first and the last beyond it).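

In this assay, methyl in place of hydrogen on the amide-type nitrogen gives a 1.4-fold higher number from compound 2 to compound 4 (0.16 log units; within the scatter), the only step shown at this position. The amide hydrogen can therefore be replaced by methyl here without a difference that repeated measurements could separate from scatter. Nothing available explains this result.

Still open, as far as these compounds go, is whether an ethyl group or a longer chain on this nitrogen would also stay this close to compound 2. Also open, from the compounds shown here alone, is whether methyl there would behave the same way on compound 1 or compound 3.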